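Larger alkyl groups on a di-N-oxide benzotriazine core

The compounds below may be only part of what the source reports. "The series", "measured", "known", "first", "only" and "open" are said of these compounds alone.

Measured compounds:
compound 1 `Cc1ccc2c(c1)[n+]([O-])c(NCCN1CCCCC1)n[n+]2[O-]` with 4000 nM
compound 2 `CCc1ccc2c(c1)[n+]([O-])c(NCCN1CCCCC1)n[n+]2[O-]` with 1500 nM
compound 3 `CC(C)c1ccc2c(c1)[n+]([O-])c(NCCN(C)C)n[n+]2[O-]` with 1900 nM

All three were tested in a functional assay on HT-29 cells (Homo sapiens) for cytotoxicity, with a stated time of 4 h; on this read-out higher numbers stand for weaker inhibition and lower numbers for stronger inhibition. Compound 1 and compound 2 share a core and differ only by methyl in place of hydrogen on a saturated chain carbon bound to an aromatic carbon, and that change gave a 2.7-fold lower number from compound 1 to compound 2 (0.43 log units; beyond the scatter). Compound 3 carries a different amine side chain and a different alkyl group than compound 1; the difference between the two cores is not broken down here.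

Compound 4 `CN(C)CCNc1n[n+]([O-])c2ccc(C(C)(C)C)cc2[n+]1[O-]` has not yet been measured in this assay. It differs from compound 3 by methyl in place of hydrogen on a saturated chain carbon bound to an aromatic carbon and two saturated chain carbons. Among the compounds with values here, this is the same kind of change as the one from compound 1 to compound 2, though not the same: in compound 4 the carbon that gains the methyl is already bound to an aromatic carbon and two saturated chain carbons, whereas in compound 2 it is bound to an aromatic carbon only.

Within the data shown here, for compound 4 a modest improvement is expected, estimated as a 1.9-fold lower number from compound 3 to compound 4 (0.28 log units; within the scatter), resting on the step from compound 1 to compound 2 of a 2.7-fold lower number from compound 1 to compound 2 (0.43 log units; beyond the scatter), with some allowance: the change is of the same kind but not identical, and only one such step is known. Compound 4 is therefore expected to give about 1000 nM, likely between 400 nM and 2500 nM.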

Compound 4, half-maximal inhibitory concentration: 3700 nM
Estimate against measurement, compound 4: 3.7-fold (0.57 log units) below; the whole stated range lies below it.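

In this assay, going from isopropyl to tert-butyl adds a single methyl and gives a 1.9-fold higher number from compound 3 to compound 4 (0.29 log units; within the scatter), so this step alone does not separate the two compounds. Set beside the earlier step, the result shows that this kind of methyl addition does not bring the same gain on every core in this series, so the earlier gain cannot simply be carried over: the same change on two cores in this assay, a 2.7-fold lower number (0.43 log units; beyond the scatter) from compound 1 to compound 2 and a 1.9-fold higher number (0.29 log units; within the scatter) from compound 3 to compound 4, 5.2-fold (0.72 log units) apart, beyond the scatter of two such steps. Within the data shown here, it does not show why the two steps part, since only two such steps are available and they differ in more than one respect: the carbon that gains the methyl is bound differently in each, and the amine side chain is not the same in the two pairs.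

The compounds shown leave open whether the two steps part through the alkyl group or through the amine side chain, which could be tested by comparing isopropyl and tert-butyl on the side chain of compound 1. They also leave open how a straight propyl chain or a cyclopropyl ring would compare with these alkyl groups in the same assay.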